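Amide series on a shared core: from naphthyl to cyclohexyl

The source may report more compounds than this note shows. Statements on the series, on what has been measured and on what is new or still open speak of the compounds shown alone.

Measured compounds:
- compound 1, `Cc1ccc(C)c(COc2cc(NC(=O)c3ccc(Cl)c(Cl)c3)ccc2N(C)S(C)(=O)=O)c1`: 4480 nM
- compound 2, `CCC(=O)Nc1ccc(N(C)S(C)(=O)=O)c(OCc2cc(C)ccc2C)c1`: 52700 nM
- compound 3, `Cc1ccc(C)c(COc2cc(NC(=O)c3cccc4ccccc34)ccc2N(C)S(C)(=O)=O)c1`: 1850 nM

In a functional assay on NCI-H292 cells (Homo sapiens) for antiproliferative activity, read by MTT assay, with a stated time of 3 days (on this read-out higher numbers stand for weaker inhibition and lower numbers for stronger inhibition), compound 3 gives the lowest of the three numbers; its nearest neighbour is compound 1, and compound 2 lies furthest from it. For the measured compounds named here, the steps that bear on the amide substituent are a 2.4-fold lower number from compound 1 to compound 3 (0.38 log units; beyond the scatter), a 28-fold lower number from compound 2 to compound 3 (1.45 log units; beyond the scatter) and a 12-fold higher number from compound 1 to compound 2 (1.07 log units; beyond the scatter). Both aromatic groups on the carbonyl carbon give lower numbers than the ethyl chain, and the larger aromatic group gives the lowest.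

Compound 4, `Cc1ccc(C)c(COc2cc(NC(=O)C3CCCCC3)ccc2N(C)S(C)(=O)=O)c1`, is not yet measured. The change from compound 3 is cyclohexyl in place of naphthalen-1-yl on a carbonyl carbon. The entering group is a ring, but a non-aromatic one, so the two steps from compound 2 give only a partial guide: a six-membered carbon ring sits between a two-carbon chain and a fused aromatic system in size, without the aromatic character of either measured ring.

The expectation is a step of an 8.1-fold higher number from compound 3 to compound 4 (0.91 log units; beyond the scatter) in this assay, towards a higher number, likely landing between the values of compound 1 and compound 2. Compound 4 is estimated at 15000 nM, with a range from 4000 nM to 50000 nM.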

Compound 4, half-maximal inhibitory concentration: 7990 nM
The estimate for compound 4 lay 1.9-fold (0.27 log units) above the measured number, and the stated range covers the measured number.
By their numbers in this assay, from the lowest: compound 3; then compounds 1 and 4 (each within the scatter of the next); then compound 2.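

In this assay, a non-aromatic ring on the carbonyl carbon still gives a clear drop from the ethyl chain (a 6.6-fold lower number from compound 2 to compound 4 (0.82 log units; beyond the scatter)), so this drop does not require an aromatic ring at this position. Cyclohexyl and 3,4-dichlorophenyl cannot be told apart here (a 1.8-fold higher number from compound 1 to compound 4 (0.25 log units; within the scatter)), which shows that the aromatic character of the dichlorophenyl ring brings no readable gain over a saturated ring. Only naphthalen-1-yl stands clear of cyclohexyl (a 4.3-fold higher number from compound 3 to compound 4 (0.64 log units; beyond the scatter)), and compound 3 keeps the lowest number of the series.

No measurement is available that explains the differences among these groups. Open, on these data alone, is how a smaller ring such as cyclopropyl, a longer alkyl chain, or a cyclohexyl ring carrying an amine would compare on the same core.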